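The source may hold more compounds than are shown below. What is called first, only, known or untested is meant among the compounds shown, and "the series" means these compounds.

Measured so far:
Compound 1 `O=C(/C=C/c1ccc(O)c(O)c1)/C=C/c1ccccc1O`: 34000 nM in an ADME assay on PC-12 cells (Rattus norvegicus) for cytotoxicity, read by WST assay, with a stated time of 24 h; a lower number here means that less compound is tolerated, a higher number that more compound is tolerated.
Compound 2 `O=C(/C=C/c1cccc(O)c1)/C=C/c1ccc(O)c(O)c1`: > 100000 nM in this assay, a limit of the assay and not a number.
Compound 3 `O=C(/C=C/c1ccccc1O)CC(=O)c1ccc(O)c(O)c1`: > 90000 nM in this assay, likewise a limit and not a number.

Among the compounds with values here, the one change seen twice is 3-hydroxyphenyl in place of 2-hydroxyphenyl on a double-bonded chain carbon bound to a double-bonded chain carbon. On the core of compound 1 it gave an at least 2.9-fold higher number from compound 1 to compound 2 (0.46 log units; beyond the scatter); the step is only a floor because compound 2 sits at the limit of > 100000 nM in this assay, at which 1 of the 3 values shown sits. Compound 3 stands at the limit of > 90000 nM in this assay, at which 1 of the 3 values shown sits, and how its core differs from that of compound 1 is not broken down here. Compound 4 `O=C(/C=C/c1cccc(O)c1)CC(=O)c1ccc(O)c(O)c1` carries the same change on the core of compound 3: 3-hydroxyphenyl in place of 2-hydroxyphenyl on a double-bonded chain carbon bound to a double-bonded chain carbon, the place being the same word for word as in the measured pair.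

Compound 3 already stands at a limit, and the same change on compound 1 carried compound 2 to the limit of > 100000 nM in this assay, at which 1 of the 3 values shown sits. For compound 4 a step that the limit leaves unreadable from compound 3 to compound 4 is expected in this assay, most likely ending in another limit rather than a number. The estimate for compound 4 is 150000 nM, expected to fall between 60000 nM and 400000 nM.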

Compound 4, half-maximal cytotoxic concentration: > 100000 nM
Compound 4: a limit, no number (the forecaster's own chance of this, stated with the estimate: 80%); the middle value is on the limit's open side.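

Compound 3 and compound 4 both sit at limits in this assay, not at numbers, and the step between them cannot be read. The compounds shown leave open where compound 2, compound 3 and compound 4 truly lie, and whether 3-hydroxyphenyl in place of 2-hydroxyphenyl does the same on both cores.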